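This account rests on a few compounds, and the source may have more. Where it says the series, first, only, none or still open, it means among the compounds named here.

Measured in a functional assay on NB1 cells (Homo sapiens) for cytotoxicity, read by MTT assay, with a stated time of 3 days; on this read-out lower numbers stand for stronger inhibition and higher numbers for weaker inhibition:
compound 1 `N#Cc1c(NN)nc(SCc2nc3ccccc3[nH]2)nc1-c1ccccc1`: 5.4 nM
compound 2 `N#Cc1c(Nc2nccs2)nc(SCc2nc3ccccc3[nH]2)nc1-c1ccccc1`: 3.2 nM
compound 3 `CN1CCN(c2nc(SCc3nc4ccccc4[nH]3)nc(-c3ccccc3)c2C#N)CC1`: 2.4 nM

Among these three, compound 3 gives 2.4 nM. Its nearest neighbour is given by a 1.3-fold lower number from compound 2 to compound 3 (0.12 log units; within the scatter), and its furthest by a 2.3-fold lower number from compound 1 to compound 3 (0.35 log units; beyond the scatter). Compound 4 `Cc1ccc(S(=O)(=O)N2CCN(c3nc(SCc4nc5ccccc5[nH]4)nc(-c4ccccc4)c3C#N)CC2)cc1` keeps the rest of compound 3 and carries (4-methylphenyl)sulfonyl in place of methyl on an amine nitrogen in a ring. Among the measured compounds shown here, no measured step changes that nitrogen, so the evidence is indirect. The closest guides are the two replacements on the aromatic carbon, and both stayed small despite exchanging whole groups. A step beyond the scatter in this assay is therefore not expected, and neither direction is favoured. The expected change is a 1.3-fold higher number from compound 3 to compound 4 (0.10 log units; within the scatter). Compound 4 is estimated at 3 nM, with an expected range of 1 nM to 10 nM.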

Compound 4, half-maximal inhibitory concentration: 6.75 nM
Compound 4: middle estimate off by 2.3-fold (0.35 log units), on the low side; measured number inside the range.
By their numbers in this assay, from the lowest: compounds 3, 2, 1 and 4 (each within the scatter of the next, the first and the last beyond it).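

In this assay, the step on the ring nitrogen is a 2.8-fold higher number from compound 3 to compound 4 (0.45 log units; beyond the scatter), so this position accepts the much larger (4-methylphenyl)sulfonyl with only a modest rise in the number. It is also the only step shown that ends at a higher number, since the earlier steps all went to lower numbers. Nothing available explains this rise.

The compounds shown leave open whether the sulfonyl or the methylphenyl ring accounts for it. They also do not show how a benzyl or an acetyl on that nitrogen would compare.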